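Swapping a dichlorophenyl for a hydroxy-methylphenyl

The source may report more compounds than this note shows. Statements on the series, on what has been measured and on what is new or still open speak of the compounds shown alone.

Compound 1 `Cc1cccc(CNc2ncnc3c2ncn3[C@@H]2O[C@H](CO)[C@@H](O)[C@H]2O)c1`: in a functional assay on G-361 cells (Homo sapiens) for antiproliferative activity, with a stated time of 72 h (a higher number here means a weaker inhibitor, a lower number a stronger inhibitor), compound 1 gives > 166000 nM, which is a limit of the assay and not a number.
Compound 2 `OC[C@H]1O[C@@H](n2cnc3c(NCc4ccc(Cl)cc4Cl)ncnc32)[C@H](O)[C@@H]1O`: in this assay compound 2 gives 128000 nM.
Compound 3 `COc1cc(O)cc(OC)c1CNc1ncnc2c1ncn2[C@@H]1O[C@H](CO)[C@@H](O)[C@H]1O`: in this assay compound 3 gives > 166000 nM, again a limit of the assay rather than a number.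

Compound 2 is thus the only one of the three with an actual number; the other two stop at a limit, and (the limit of > 166000 nM in this assay, at which 2 of the 3 values shown sit). Within the data shown here, the single measured step, an at least 1.2-fold lower number from compound 1 to compound 2 (0.11 log units; that floor lies within the scatter), lies within the scatter, so it shows no trustworthy change in potency.

Compound 4 `Cc1cccc(CNc2ncnc3c2ncn3[C@@H]2O[C@H](CO)[C@@H](O)[C@H]2O)c1O` has not yet been measured. Relative to compound 2, (2-hydroxy-3-methylphenyl in place of 2,4-dichlorophenyl on a saturated chain carbon bound to a nitrogen on an aromatic ring). Among the measured compounds shown here, no measured step introduces a hydroxy group or the 2-hydroxy-3-methylphenyl, so nothing bears directly on this change; the only measured step, from 3-methylphenyl to 2,4-dichlorophenyl, was within the scatter. Compound 1 carries 3-methylphenyl and sits at a limit, and compound 3 carries a hydroxy-bearing ring and also sits at a limit. The expected step of a 1.3-fold higher number from compound 2 to compound 4 (0.10 log units; within the scatter) is therefore none beyond the scatter, with a real chance that only a limit is reported. Compound 4 is estimated at 160000 nM, in the range 60000 nM to 400000 nM.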

Compound 4, half-maximal inhibitory concentration: > 166000 nM
Compound 4: a limit, no number; the forecaster's own chance of this, stated with the estimate: 60%; middle value at least 1.0-fold (0.01 log units) from the limit.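

In this assay, 2-hydroxy-3-methylphenyl in place of 2,4-dichlorophenyl on a saturated chain carbon bound to a nitrogen on an aromatic ring gives an at least 1.2-fold higher number from compound 2 to compound 4 (0.11 log units; that floor lies within the scatter), so this change shows no trustworthy shift in potency. Compound 4 sits at a limit of the assay and not at a number, and the step from compound 1, hydroxy in place of hydrogen on an aromatic carbon, cannot be read. Of the four rings now shown at this position, only the one in compound 2 gives a number, so the new result adds a third compound to those without one: the limit of > 166000 nM in this assay, at which 3 of the 4 values shown sit.

From the compounds shown here alone, what a hydroxy group does to potency here stays open, and it could only be read on a ring whose compound gives a number, such as the 2,4-dichlorophenyl of compound 2. Going by these compounds, it is also open whether any other group at this position, such as an amine or a carboxylic acid on the ring, or a longer chain carrying the ring, would give a number clearly lower than that of compound 2.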